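The source may report more compounds than this note shows. Statements on the series, on what has been measured and on what is new or still open speak of the compounds shown alone.

Compound 1 `CC(=O)c1ccc(OCc2cccc(C)c2)cc1` carries a methyl on its outer ring. In an assay on isolated protein for inhibition of Amine oxidase [flavin-containing] A (Homo sapiens), read by Amplex Red, with a stated time of 15 min, tested at 100 uM (on this read-out higher numbers stand for more inhibition at the one concentration tested (going by the name of the read-out) and lower numbers for less inhibition), compound 1 gives 32.3%. Compound 2 `CC(=O)c1ccc(OCc2cccc(C(F)(F)F)c2)cc1` differs from compound 1 only by the change (trifluoromethyl in place of methyl on an aromatic carbon), and the measured step is a number 16.6 percentage points higher from compound 1 to compound 2 (beyond the scatter). Compound 2 gives 48.9% in this assay, its gaps to compound 1 and compound 3 both beyond the scatter. Compound 3 `CC(=O)c1cccc(OCc2cccc(C)c2)c1` is built from the same atoms as compound 1, joined differently; the difference between the two cores is not broken down here. In this assay compound 3 gives 31.1%, a number within the scatter of compound 1, so no difference is read between them.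

Compound 4 `CC(=O)c1cccc(OCc2cccc(C(F)(F)F)c2)c1` is not yet measured. It stands to compound 3 as compound 2 stands to compound 1: the change (trifluoromethyl in place of methyl on an aromatic carbon), at a place described in the same words, hence the same change on the core of compound 3. Going by the values given here, only one prior instance exists. Among the compounds with values here, from compound 3 to compound 4 a step of about a number 15.9 percentage points higher from compound 3 to compound 4 (beyond the scatter) is expected in this assay, because a number 16.6 percentage points higher from compound 1 to compound 2 (beyond the scatter) is the sole measured example. Compound 4 is therefore estimated at 47%, within 36% to 58%.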

Compound 4, a percentage reported as inhibition, at one concentration (the size of the read-out at that concentration, not a potency): 46.7%
The estimate for compound 4 lay 0.3 percentage points above the measured number; measured number inside the range.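

On the core of compound 3, trifluoromethyl in place of methyl on an aromatic carbon gives in this assay a number 15.6 percentage points higher from compound 3 to compound 4 (beyond the scatter). The step carries over between these two cores, and no difference is read between its two instances: the same change on two cores in this assay, a number 16.6 percentage points higher (beyond the scatter) from compound 1 to compound 2 and a number 15.6 percentage points higher (beyond the scatter) from compound 3 to compound 4, 1 percentage points apart, within the scatter of two such steps

This rests on two matched pairs and a single read-out at one concentration, so it shows transfer between these two cores only; it does not show that the step would hold on any other core, at another place on the ring, or at another concentration.

Open, as far as these compounds go, is how a nitrile, an amine or a carboxylic acid would read in this assay at the place held by the methyl and the trifluoromethyl, and whether the step would then keep its size on both cores. Also open, from the compounds shown here alone, is whether a longer chain on the carbonyl would leave the same step intact.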